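Vero cytotoxicity notes on three measured analogues and one pending

The compounds below may be only part of what the source reports. "The series", "measured", "known", "first", "only" and "open" are said of these compounds alone.

Measured so far:
- compound 1 `CCO/N=C1/C(=O)N(Cc2cn(CC(=O)N3CCN(c4cc5c(cc4F)c(=O)c(C(=O)O)cn5C4CC4)CC3)nn2)c2ccccc21`: 64 ug/mL
- compound 2 `CCO/N=C1/C(=O)N(Cc2cn(CC(=O)N3CCN(c4cc5c(cc4F)c(=O)c(C(=O)O)cn5C4CC4)CC3)nn2)c2c(F)cccc21`: 16 ug/mL
- compound 3 `CO/N=C1/C(=O)N(Cc2cn(CC(=O)N3CCN(c4cc5c(cc4F)c(=O)c(C(=O)O)cn5C4CC4)CC3)nn2)c2ccc(F)cc21`: 64 ug/mL

All three numbers come from an ADME assay on Vero cells (Chlorocebus sabaeus) for cytotoxicity; on this read-out higher numbers stand for lower toxicity in this test and lower numbers for higher toxicity in this test. For the measured compounds named here, the one counted step is a 4.0-fold higher number from compound 2 to compound 1 (0.60 log units; beyond the scatter), made by hydrogen in place of fluoro on an aromatic carbon. Compound 3 sits level with compound 1 at the digits given, within the scatter, and its number is higher than that of compound 2 beyond the scatter; the difference between the cores of compound 2 and compound 3 is not broken down here.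

Compound 4 `CO/N=C1/C(=O)N(Cc2cn(CC(=O)N3CCN(c4cc5c(cc4F)c(=O)c(C(=O)O)cn5C4CC4)CC3)nn2)c2ccccc21` is not yet measured in this assay. It arises from compound 3 by hydrogen in place of fluoro on an aromatic carbon. This is the same kind of change as the earlier one, but the place differs: there the carbon was ortho to a fused ring and meta to a fused ring, here it is meta to a fused ring and para to a fused ring. The expected step is a 1.4-fold higher number from compound 3 to compound 4 (0.15 log units; within the scatter), smaller than the earlier one, because compound 3 already gives 64 ug/mL, the top of the set, and the place is not the same. Compound 4 is estimated at 90 ug/mL, between 40 ug/mL and 200 ug/mL.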

Compound 4, half-maximal cytotoxic concentration: 128 ug/mL
Compound 4: the middle estimate sits 1.4-fold (0.15 log units) below what was measured; the measured number falls inside the stated range.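

In this assay, hydrogen in place of fluoro on an aromatic carbon gives a 2.0-fold higher number from compound 3 to compound 4 (0.30 log units; within the scatter), and the two cases of this change compare as follows: the same change on two cores in this assay, a 4.0-fold higher number (0.60 log units; beyond the scatter) from compound 2 to compound 1 and a 2.0-fold higher number (0.30 log units; within the scatter) from compound 3 to compound 4, 2.0-fold (0.30 log units) apart, within the scatter of two such steps. For the compounds shown here, the two step sizes therefore cannot be told apart on these cores, although only the step on the core of compound 1 lies beyond the scatter. Going by these compounds alone, this does not establish a general transfer: there are only two pairs, the fluoro sits at a different place in each, and the cores also differ in the chain on the oxygen, where hydrogen in place of methyl on a saturated chain carbon bound to an oxygen on an unsaturated carbon gives a 2.0-fold higher number from compound 1 to compound 4 (0.30 log units; within the scatter).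

The compounds shown leave open how chloro or an amine on the same aromatic carbon would read in this assay. They also leave open whether a longer chain on the oxygen would keep the read-out in the range seen here.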